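The source may report more compounds than this note shows. Statements on the series, on what has been measured and on what is new or still open speak of the compounds shown alone.

Working notes on the series. Compound 1 `Cc1ccccc1Nc1nc(Nc2cccnc2)ncc1Cl` gives 41200 nM in a functional assay on MDA-MB-231 cells (Homo sapiens) for inhibition, read by CCK-8 assay, with a stated time of 48 h (on this read-out lower numbers stand for stronger inhibition of growth and higher numbers for weaker inhibition of growth), compound 2 `Cc1ccccc1Nc1nc(Nc2ccc(N3CCN(C(=O)OC(C)(C)C)CC3)cc2)ncc1Cl` gives 3260 nM, and compound 3 `CN1CCN(c2ccc(Nc3ncc(Cl)c(NCc4ccc(C(F)(F)F)cc4)n3)nc2)CC1` gives 19100 nM. On these three numbers compound 3 stands second highest: it lies below compound 1 and above compound 2, and both gaps exceed the scatter.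

Compound 4 `CC(C)c1cccc(Nc2nc(Nc3ccc(N4CCN(C)CC4)cn3)ncc2Cl)c1` is not yet measured. Change from compound 3: 3-isopropylphenyl in place of 4-(trifluoromethyl)benzyl on a nitrogen on an aromatic ring. Going by the values given here, no measured pair in the set isolates this exact change. Because compound 2 gives 3260 nM with an aryl group on the same kind of nitrogen, a step toward lower numbers in this assay is expected, of moderate size. The step of a 3.5-fold lower number from compound 3 to compound 4 (0.54 log units; beyond the scatter) is the estimate. Compound 4 is estimated at 5500 nM, between 1500 nM and 20000 nM.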

Compound 4, concentration for 50% growth inhibition: 5590 nM
For compound 4 the middle estimate is 1.0-fold (0.01 log units) below the measured one, within the range that was stated.
By their numbers in this assay, from the lowest: compounds 2 and 4 (each within the scatter of the next); then compound 3; then compound 1.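

Replacing 4-(trifluoromethyl)benzyl with 3-isopropylphenyl on a nitrogen on an aromatic ring gives a 3.4-fold lower number from compound 3 to compound 4 (0.53 log units; beyond the scatter) in this assay, so the read-out responds to the group at this position. Benzyl gives way to phenyl and the ring substituent changes in the same step, so the modest shift cannot be divided between the two. Nothing at hand explains the step.

On these data alone, how an unsubstituted phenyl would compare at this position remains open. So does the effect of a carboxylic acid or an amine in place of the isopropyl group.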